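Ortho group exchange on the anilino arm: compound 4

The compounds below may be only part of what the source reports. "The series", "measured", "known", "first", "only" and "open" are said of these compounds alone.

Within the data shown here, compound 3 `CSc1ccccc1Nc1nc2c(Nc3ccc(C(F)(F)F)cc3)ncnc2s1` gives 43 nM in a functional assay on HEK293 cells for antagonist activity at transient receptor potential cation channel subfamily V member 1 (Homo sapiens), read by calcium flux (on this read-out higher numbers stand for weaker inhibition and lower numbers for stronger inhibition), the lowest of the three numbers so far. Compound 2 `FC(F)(F)c1ccc(Nc2ncnc3sc(Nc4ccccc4Cl)nc23)cc1` gives 64 nM; the step of a 1.5-fold lower number from compound 2 to compound 3 (0.17 log units; within the scatter) stays within the scatter. Compound 1 `CN(c1nc2c(Nc3ccc(C(F)(F)F)cc3)ncnc2s1)c1c(Cl)cccc1Cl` gives 502 nM, and both a 12-fold lower number from compound 1 to compound 3 (1.07 log units; beyond the scatter) and a 7.8-fold lower number from compound 1 to compound 2 (0.89 log units; beyond the scatter) lie beyond the scatter. Compound 4 `FC(F)(F)c1ccc(Nc2ncnc3sc(Nc4ccccc4C(F)(F)F)nc23)cc1` differs from compound 3 by trifluoromethyl in place of methylsulfanyl on an aromatic carbon. Among the measured compounds shown here, the one measured step that bears on this exchange is a 1.5-fold lower number from compound 2 to compound 3 (0.17 log units; within the scatter), which did not move beyond the scatter, so a further exchange of the group at the same place is expected to give no step beyond the scatter, a 1.5-fold higher number from compound 3 to compound 4 (0.18 log units; within the scatter). Compound 4 is therefore estimated at 65 nM, within 25 nM to 180 nM.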

Compound 4, half-maximal inhibitory concentration: 74 nM
Beside the measured number, compound 4's estimate is 1.1-fold (0.06 log units) below it; low and high end bracket the measured number.
By their numbers in this assay, from the lowest: compounds 3, 2 and 4 (each within the scatter of the next); then compound 1.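

In this assay, trifluoromethyl at this place gives a 1.7-fold higher number from compound 3 to compound 4 (0.24 log units; within the scatter) and a 1.2-fold higher number from compound 2 to compound 4 (0.06 log units; within the scatter), so the steps stay within the scatter. The earlier compounds shown here showed this for chloro and methylsulfanyl only; a third group, with more heavy atoms and no hydrogen-bond acceptor, now gives the same picture. Nothing at hand explains this.

As far as these compounds go, whether a group of another kind at this place, such as a primary amine or a carboxylic acid, stays within the scatter remains open. So does the effect of hydrogen there, with no group at all on that carbon.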